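The source may hold more compounds than are shown below. What is called first, only, known or untested is meant among the compounds shown, and "the series" means these compounds.

Compound 1 `O=C(NC1CCN(Cc2cccc(Cl)c2)CC1)c1cccc2ccccc12`, in an assay on isolated protein for displacement of a labelled ligand from D(4) dopamine receptor (Homo sapiens); on this read-out higher numbers stand for weaker inhibition and lower numbers for stronger inhibition: 116 nM
Compound 2 `O=C(NC1CCN(Cc2ccc(Br)cc2)CC1)c1cccc2ccccc12`, in this assay : 44 nM

Compound 2 gives the lowest of the two numbers; its nearest neighbour is compound 1, and the gap between them is a 2.6-fold lower number from compound 1 to compound 2 (0.42 log units; beyond the scatter). Compound 3 `O=C(NC1CCN(Cc2cccc(C(F)(F)F)c2)CC1)c1cccc2ccccc12` carries 3-(trifluoromethyl)phenyl in place of 4-bromophenyl on a saturated chain carbon bound to an amine nitrogen in a ring. Among the compounds with values here, no measured step matches this exchange; the only step that bears on it, a 2.6-fold lower number from compound 1 to compound 2 (0.42 log units; beyond the scatter), shows that the 3-substituted phenyl gave the higher number. Compound 3 is therefore expected to show a 2.3-fold higher number from compound 2 to compound 3 (0.36 log units; beyond the scatter). The estimate for compound 3 is 100 nM, with a range of 35 nM to 300 nM.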

Compound 3, inhibition constant: 119 nM
Beside the measured number, compound 3's estimate is 1.2-fold (0.08 log units) below it; the range from low to high includes it.
By their numbers in this assay, from the lowest: compound 2; then compounds 1 and 3 (each within the scatter of the next).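

Trifluoromethyl in place of chloro on an aromatic carbon gives a 1.0-fold higher number from compound 1 to compound 3 (0.01 log units; within the scatter), so this exchange has no readable effect in this assay. By contrast, 3-(trifluoromethyl)phenyl in place of 4-bromophenyl gives a 2.7-fold higher number from compound 2 to compound 3 (0.43 log units; beyond the scatter), leaving compound 2 apart from both other compounds. Nothing available explains this difference.

The compounds shown do not separate the identity of the substituent from where it sits on the phenyl ring, since the 4-bromophenyl group has no 3-bromophenyl counterpart here. Going by these compounds, how a methoxy group or a nitrile would behave at this position remains open.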